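A few compounds are considered here, and "the series" means these few. Any claim that something is new, unique, unknown or untested is made for them only; others in the source may bear on it.

Measured so far in an ADME assay on K562 cells (Homo sapiens) for cytotoxicity, with a stated time of 72 h; a higher number here means a weaker inhibitor, a lower number a stronger inhibitor:
compound 1, `COc1ccccc1CNc1ncnc2c1ncn2C1CCCCO1`, gives 97000 nM;
compound 2, `COc1cccc(OC)c1CNc1ncnc2c1ncn2C1CCCCO1`, gives 10300 nM;
compound 3, `COc1ccc(CNc2ncnc3c2ncn3C2CCCO2)cc1`, gives only a limit of the assay, > 100000 nM.

Compound 1 and compound 2 share one core and differ in a single place: methoxy in place of hydrogen on an aromatic carbon. That change made a step of a 9.4-fold lower number from compound 1 to compound 2 (0.97 log units; beyond the scatter). Compound 3 is built on a different core; the difference between the two cores is not broken down here. For compound 3 the reading is a limit of the assay and not a number, which is where the limit of > 100000 nM in this assay, at which 1 of the 3 values shown sits, sits.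

Compound 4, `COc1ccc(CNc2ncnc3c2ncn3C2CCCO2)cc1OC`, has not yet been measured. It differs from compound 3 by methoxy in place of hydrogen on an aromatic carbon. Within the data shown here, this is the same kind of change as the one from compound 1 to compound 2, but not the same: in compound 2 the entering methoxy sits ortho to a large group and meta to a methoxy group, whereas in compound 4 it sits ortho to a methoxy group and meta to a large group.

The step from compound 3 to compound 4 is expected to be roughly an at least 2.0-fold lower number from compound 3 to compound 4 (0.30 log units; that floor lies within the scatter), resting on the measured step of a 9.4-fold lower number from compound 1 to compound 2 (0.97 log units; beyond the scatter), with wide uncertainty since compound 3 gave only a limit. Compound 4 is therefore estimated at 50000 nM in this assay, expected to lie between 12000 nM and 200000 nM.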

Compound 4, half-maximal inhibitory concentration: > 100000 nM
Compound 4: no number, only a limit (the forecaster's own chance of this, stated with the estimate: 40%); at least 2.0-fold (0.30 log units) between middle value and limit.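

In this assay compound 3 and compound 4 each give only a limit of the assay and not a number, so the step between these two compounds cannot be read. The compounds shown leave open whether methoxy in place of hydrogen lowers the number at all on the core of compound 3, as it did on the core of compound 1.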